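A few compounds are considered here, and "the series" means these few. Any claim that something is new, unique, unknown or untested is made for them only; others in the source may bear on it.

In a functional assay on LOX IMVI cells (Homo sapiens) for cytotoxicity, read by MTT assay, with a stated time of 24 h (on this read-out higher numbers stand for weaker inhibition and lower numbers for stronger inhibition), compound 1 (`COc1cc(-c2nc(-c3ccccc3)[nH]c2-c2ccnc(NCCCNS(=O)(=O)c3ccc(Br)cc3)n2)ccc1F`) gives 33900 nM, compound 2 (`COc1cc(-c2nc(-c3ccccc3)[nH]c2-c2ccnc(NCCCNS(=O)(=O)c3ccc(Br)cc3)n2)ccc1Cl`) gives 23700 nM and compound 3 (`O=S(=O)(NCCCNc1nccc(-c2[nH]c(-c3ccccc3)nc2-c2ccc(Cl)c(O)c2)n1)c1ccc(Cl)cc1`) gives 61300 nM. The number for compound 3 lies within the scatter of that for compound 1, and beyond the scatter above that for compound 2. Compound 4 (`O=S(=O)(NCCCNc1nccc(-c2[nH]c(-c3ccccc3)nc2-c2ccc(Cl)c(O)c2)n1)c1ccc(Br)cc1`) differs from compound 3 in one place, with (4-bromophenyl)sulfonyl in place of (4-chlorophenyl)sulfonyl: bromo in place of chloro on an aromatic carbon. For the measured compounds named here, no measured step shows this exchange. The nearest one, a 1.4-fold lower number from compound 1 to compound 2 (0.16 log units; within the scatter), is chloro in place of fluoro at another place on an aromatic carbon, so only a step within the scatter is expected in this assay, with no firm direction. The expected step is a 1.2-fold lower number from compound 3 to compound 4 (0.09 log units; within the scatter). Compound 4 is estimated at 50000 nM, with an expected range of 27000 nM to 90000 nM.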

Compound 4, half-maximal inhibitory concentration: 15500 nM
Compound 4: the middle estimate sits 3.2-fold (0.51 log units) above what was measured, outside the stated range (below it).
By their numbers in this assay, from the lowest: compounds 4, 2, 1 and 3 (each within the scatter of the next, the first and the last beyond it).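

In this assay, the halogen on the phenylsulfonyl group proves able to shift the number beyond the scatter: bromo in place of chloro, para to a large group, gives a 4.0-fold lower number from compound 3 to compound 4 (0.60 log units; beyond the scatter) for this pair. With bromo kept, hydrogen in place of methyl on the oxygen gives only a 1.5-fold lower number from compound 2 to compound 4 (0.18 log units; within the scatter) while 4-chloro-3-hydroxyphenyl in place of 4-fluoro-3-methoxyphenyl gives a 2.2-fold lower number from compound 1 to compound 4 (0.34 log units; beyond the scatter) across the two changes together. Nothing measured here explains the bromo step. As far as these compounds go, whether iodo, an amine or a carboxylic acid at this position would extend the step remains open, as does whether it recurs on the 4-chloro-3-methoxyphenyl compounds.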